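Extending the sulfonyl aryl of compound 2 toward compound 4

A few compounds are considered here, and "the series" means these few. Any claim that something is new, unique, unknown or untested is made for them only; others in the source may bear on it.

Measured compounds:
Compound 1 `N/C(=N\O)c1ccc(C(=O)CS(=O)(=O)c2ccccc2)cc1`: > 125000 nM
Compound 2 `N/C(=N\O)c1ccc(C2=C(S(=O)(=O)c3ccccc3)CC(c3ccccc3)(c3ccccc3)O2)cc1`: 30600 nM
Compound 3 `CC1(c2ccccc2)CC(S(=O)(=O)c2ccc(/C(N)=N/O)cc2)=C(c2ccccc2)O1`: 54700 nM

Of the compounds shown here, three have been tested in an ADME assay on THP-1 cells (Homo sapiens) for cytotoxicity, read by flow cytometry, with a stated time of 72 h; on this read-out lower numbers stand for stronger inhibition and higher numbers for weaker inhibition. Compound 1 reaches only a limit of the assay, > 125000 nM, so no number is available for it (the limit of > 125000 nM in this assay, at which 1 of the 3 values shown sits). Compound 2 gives 30600 nM, the lowest of the two numbers; compound 3 gives 54700 nM, and the two values lie within the usual scatter of this assay, so no order between them can be claimed.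

Compound 4 `N/C(=N\O)c1ccc(C2=C(S(=O)(=O)c3ccc(Nc4cccc(/C(N)=N/O)c4)cc3)CC(c3ccccc3)(c3ccccc3)O2)cc1` has not yet been measured. Relative to compound 2, the change is a group of 11 heavy atoms (7 carbon, 3 nitrogen, 1 oxygen; one six-membered aromatic ring of carbon only) in place of a hydrogen atom, on an aromatic carbon, para to a large group. Within the data shown here, no measured pair differing in just this way is available, so there is no step from which to read the size of the effect. The expectation is therefore that compound 4 stays close to compound 2, with a step in this assay of a 1.3-fold higher number from compound 2 to compound 4 (0.12 log units; within the scatter) that is expected to fall within the scatter or slightly toward a higher number. Compound 4 is estimated at 40000 nM, with a range from 15000 nM to 110000 nM.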

Compound 4, half-maximal inhibitory concentration: > 50000 nM
Compound 4 gave a limit, no number; the forecaster's own chance of this, stated with the estimate: 15%; middle value at least 1.2-fold (0.09 log units) away from the limit.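

The change from a hydrogen atom to a group of 11 heavy atoms (7 carbon, 3 nitrogen, 1 oxygen; one six-membered aromatic ring of carbon only), on an aromatic carbon para to a large group, gives the first step read at this position in this assay: an at least 1.6-fold higher number from compound 2 to compound 4 (0.21 log units; that floor lies within the scatter). The result therefore shows that this large group, placed on the sulfonyl aryl of compound 2, brings no lower number in this read-out, although the floor of the step does not establish a real rise. The value of compound 4 is a limit of the assay and not a number: the limit of > 50000 nM in this assay, at which 1 of the 4 values shown sits.

Going by these compounds, how far the true value of compound 4 lies beyond that limit stays open, and with it whether the step from the hydrogen atom exceeds the usual scatter at all. Also open, on these data alone, is whether a much smaller group on the same aromatic carbon, such as an amine or a carboxylic acid, would leave the read-out equally unmoved, or whether a group of this size is needed for the result seen here.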